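The compounds below may be only part of what the source reports. "The series", "measured", "known", "first", "only" and "open" are said of these compounds alone.

Measured compounds:
- Compound 1, `COc1cc(OC)cc(-c2cc3ccccc3c(-c3cccc(N)c3)n2)c1`, gives > 50000 nM in an ADME assay on MCF-10A cells (Homo sapiens) for cytotoxicity, read by CCK-8 assay and cell counting, with a stated time of 72 h (on this read-out lower numbers stand for stronger inhibition and higher numbers for weaker inhibition), a value that is a limit of the measurement and not a number.
- Compound 2, `COc1ccc(-c2cc3cc(C)ccc3c(-c3cccc(O)c3)n2)c(C)c1`, gives 5050 nM in this assay.
- Compound 3, `COc1cccc(-c2nc(-c3ccc(OC)c(OC)c3)cc3cc(C)ccc23)c1`, gives > 50000 nM in this assay, again a limit of the measurement rather than a number.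

Compound 3 therefore stands at the edge of what this assay can report: for it only a limit is known, and it shares that position with compound 1, as the limit of > 50000 nM in this assay, at which 2 of the 3 values shown sit, shows. For the measured compounds named here, compound 2 is the only compound of the three for which a number was obtained.

Compound 4, `COc1ccc(-c2nc(-c3ccc(OC)c(OC)c3)cc3cc(C)ccc23)cc1`, differs from compound 3 in one place: 4-methoxyphenyl in place of 3-methoxyphenyl on an aromatic carbon. Both hold the same atoms, joined differently, with the methoxy group moved within the phenyl ring that sits next to the ring nitrogen, ortho to a fused ring, meta to a fused ring and meta to a large group.

Going by the values given here, no measured step between compounds connects this change to a value, so the expectation rests on where compound 3 sits. Since compound 3 and compound 1 both lie at the limit, compound 4 is expected to give 50000 nM in this assay, within 15000 nM to 150000 nM. The expected step from compound 3 to compound 4 is a number no higher from compound 3 to compound 4 (the limit leaves the size open), meaning no movement beyond the usual scatter, with the result most likely again reported only as a limit.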

Compound 4, half-maximal inhibitory concentration: > 50000 nM
Compound 4: a limit, no number; the forecaster's own chance of this, stated with the estimate: 70%; the middle value lies on the limit itself.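

Compound 3 and compound 4 both sit at a limit of the measurement in this assay, so no step can be read between them. That limit is shared more widely now: the limit of > 50000 nM in this assay, at which 3 of the 4 values shown sit. The compounds shown leave open whether 4-methoxyphenyl in place of 3-methoxyphenyl changes the read-out at all.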